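The source may hold more compounds than are shown below. What is called first, only, known or untested is meant among the compounds shown, and "the series" means these compounds.

Going by the values given here, in a functional assay on K562 cells (Homo sapiens) for cytotoxicity, read by fluorescence, with a stated time of 72 h (a lower number here means a stronger inhibitor, a higher number a weaker inhibitor), compound 1 `CC(C)c1n[nH]c2c(NCc3ccc(-c4ccccn4)cc3)nc(N3CCCCC3CCO)nc12` gives 165 nM and compound 2 `CC(C)c1n[nH]c2c(NCc3ccc(-c4ccccn4)cc3)nc(N[C@@H]3CCCC[C@H]3N)nc12` gives 175 nM, so compound 2 stands level with the only other measured compound. Among the compounds with values here, the one measured step, a 1.1-fold higher number from compound 1 to compound 2 (0.03 log units; within the scatter), replaces 2-(2-hydroxyethyl)piperidin-1-yl with (2-aminocyclohexyl)amino and stays within the scatter. Compound 3 `CC(C)c1n[nH]c2c(NCc3ccc(-c4ccccn4)cc3)nc(NCC(N)CO)nc12` has 2-amino-3-hydroxypropyl in place of 2-aminocyclohexyl on a nitrogen on an aromatic ring. Within the data shown here, no measured step removes a ring in this way, so that small step is only a weak guide, and a small rise in this assay is expected. The expected change is a 1.4-fold higher number from compound 2 to compound 3 (0.15 log units; within the scatter). For compound 3 the estimate is 250 nM, with a range of 90 nM to 700 nM.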

Compound 3, half-maximal inhibitory concentration: 700 nM
The estimate for compound 3 lay 2.8-fold (0.45 log units) below the measured number; the measured number falls inside the stated range.
By their numbers in this assay, from the lowest: compounds 1 and 2 (each within the scatter of the next); then compound 3.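

In this assay, going by these compounds alone, 2-amino-3-hydroxypropyl in place of 2-aminocyclohexyl on a nitrogen on an aromatic ring gives a 4.0-fold higher number from compound 2 to compound 3 (0.60 log units; beyond the scatter) and is the first step here beyond the scatter, so the number responds to the group at this place. The same open chain set against the 2-(2-hydroxyethyl)piperidin-1-yl group gives a 4.2-fold higher number from compound 1 to compound 3 (0.63 log units; beyond the scatter) and leaves both ring-bearing groups with lower numbers than the open chain.

Still open, on these data alone, is whether the rise follows the loss of the ring or the added hydroxyl; 2-aminoethyl or 2-hydroxycyclohexyl at this place would separate the two. Nothing at hand explains the rise.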